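Swapping 4-Phenylphenyl for 1,3-Thiazol-2-yl in a Cytotoxicity Series

A few compounds are considered here, and "the series" means these few. Any claim that something is new, unique, unknown or untested is made for them only; others in the source may bear on it.

Compound 3 `c1ccc(-c2ccc(C(c3ccccc3)N3CCN(c4ncnc5c4cnn5-c4ccccc4)CC3)cc2)cc1` is known only by a limit: in a functional assay on cells (Rhabdomyosarcoma cell, Homo sapiens) for cytotoxicity (a lower number here means a stronger inhibitor, a higher number a weaker inhibitor), compound 3 gives > 25000 nM. Compound 1 `Cc1ccsc1C(c1c(C)noc1C)N1CCN(c2ncnc3c2cnn3-c2ccccc2)CC1` likewise sits at a limit, giving > 25000 nM in this assay. Compound 2 `Cc1ccsc1C(c1ccccc1Br)N1CCN(c2ncnc3c2cnn3-c2ccccc2)CC1` also returns a limit, > 25000 nM in this assay. Among the measured compounds shown here, the single measured step, a step that the two limits leave unreadable from compound 1 to compound 2, is therefore unreadable, and the whole series rests on (the limit of > 25000 nM in this assay, at which 3 of the 3 values shown sit). Compound 4 `c1ccc(C(c2nccs2)N2CCN(c3ncnc4c3cnn4-c3ccccc3)CC2)cc1` differs from compound 3 by 1,3-thiazol-2-yl in place of 4-phenylphenyl on a saturated chain carbon bound to an amine nitrogen in a ring and an aromatic carbon. For the measured compounds named here, no measured step reads on this change, and every value so far sits at the limit. Compound 4 is expected to give 30000 nM in this assay, somewhere between 10000 nM and 100000 nM. The estimated step, a step that the limit leaves unreadable from compound 3 to compound 4, is expected to be none beyond the scatter.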

Compound 4, half-maximal inhibitory concentration: > 25000 nM
Compound 4: only a limit was reported; the forecaster's own chance of this, stated with the estimate: 80%; the middle value is on the limit's open side.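

Compound 3 and compound 4 both stand at a limit in this assay, so the step between them cannot be read: the limit of > 25000 nM in this assay, at which 4 of the 4 values shown sit. The compounds shown leave open how strong any of them actually is in this assay.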